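The source may report more compounds than this note shows. Statements on the series, on what has been measured and on what is new or still open speak of the compounds shown alone.

Three compounds share one core and differ only in the group on the outer benzene ring. In a functional assay on MDA-MB-231 cells (Homo sapiens) for inhibition, read by MTT assay, with a stated time of 24 h (a lower number here means a stronger inhibitor, a higher number a weaker inhibitor), compound 1 (`C(=N/c1ccccc1)\c1cc(-c2ccccc2)no1`) gives > 100000 nM, which is a limit of the assay rather than a number. Compound 2 (`Fc1ccc(-c2cc(/C=N/c3ccccc3)on2)cc1`) gives 41200 nM in this assay, and compound 3 (`Cc1ccc(-c2cc(/C=N/c3ccccc3)on2)cc1`) gives 29400 nM. Two steps move away from the limit: an at least 2.4-fold lower number from compound 1 to compound 2 (0.38 log units; beyond the scatter) and an at least 3.4-fold lower number from compound 1 to compound 3 (0.53 log units; beyond the scatter). Between the two numbered compounds there is only a 1.4-fold lower number from compound 2 to compound 3 (0.15 log units; within the scatter). Compound 3 thus holds the lowest of the two numbers, with compound 2 within the scatter of it.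

Compound 4 (`FC(F)(F)c1ccc(-c2cc(/C=N/c3ccccc3)on2)cc1`) differs from compound 3 by trifluoromethyl in place of methyl on an aromatic carbon. Within the data shown here, no measured step swaps a methyl for a trifluoromethyl; the nearest guide is the swap from fluoro to methyl, which stayed within the scatter, so no step beyond the scatter is expected here, in either direction. Compound 4 is therefore estimated at 30000 nM, with a range from 9000 nM to 100000 nM. That estimate amounts to a 1.0-fold higher number from compound 3 to compound 4 (0.01 log units; within the scatter), an expectation awaiting the measurement.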

Compound 4, half-maximal inhibitory concentration: 37400 nM
Beside the measured number, compound 4's estimate is 1.2-fold (0.10 log units) below it; the range from low to high includes it.
By their numbers in this assay, from the lowest: compounds 3, 4 and 2 (each within the scatter of the next). At a limit, above all of these: compound 1.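

At this place, on an aromatic carbon para to a large group, going from 1 heavy atom in methyl to 4 in trifluoromethyl gives a 1.3-fold higher number from compound 3 to compound 4 (0.10 log units; within the scatter) in this assay, and the swap from fluoro gives a 1.1-fold lower number from compound 2 to compound 4 (0.04 log units; within the scatter). Fluoro, methyl and trifluoromethyl therefore cannot be told apart here, and size shows no trend across compound 2, compound 3 and compound 4. Compared with hydrogen there is an at least 2.6-fold lower number from compound 1 to compound 4 (0.42 log units; beyond the scatter), but compound 1 stands at a limit, so this step is only a bound: the limit of > 100000 nM in this assay, at which 1 of the 4 values shown sits.

As far as these compounds go, how far any of these three groups truly lies from hydrogen remains open. So does whether an amine, a carboxylic acid or a longer chain at this place would give a number beyond the scatter of these three.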